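Aryl ketone variation on the shared core: cytotoxicity notes

This account rests on a few compounds, and the source may have more. Where it says the series, first, only, none or still open, it means among the compounds named here.

Measured so far:
Compound 1, `COc1cc(-c2nnc3n2NC(c2ccco2)C(C(=O)c2cccs2)S3)cc(OC)c1OC` — in a functional assay on PC-3 cells (Homo sapiens) for cytotoxicity, read by MTT assay, with a stated time of 48 h (a lower number here means a stronger inhibitor, a higher number a weaker inhibitor), compound 1 gives 46200 nM.
Compound 2, `COc1cc(-c2nnc3n2NC(c2ccco2)C(C(=O)c2ccc(O)cc2)S3)cc(OC)c1OC` — in this assay compound 2 gives 38300 nM.

Compound 2 holds the lower of the two numbers, but its separation from compound 1 is only a 1.2-fold lower number from compound 1 to compound 2 (0.08 log units; within the scatter), so the two stand within the scatter and no order between them can be claimed.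

Compound 3, `COc1cccc(C(=O)C2Sc3nnc(-c4cc(OC)c(OC)c(OC)c4)n3NC2c2ccco2)c1`, is not yet measured. It differs from compound 2 in one place: 3-methoxyphenyl in place of 4-hydroxyphenyl on a carbonyl carbon. Going by the values given here, the one measured step that touches this site is the exchange of the group on the carbonyl carbon between compound 1 and compound 2, and that step was a 1.2-fold lower number from compound 1 to compound 2 (0.08 log units; within the scatter), within the scatter. The swap of one six-membered aromatic ring of carbon only for another at the same place therefore gives no ground for expecting a change beyond the scatter, in either direction.

For compound 3 in this assay the expected value is 40000 nM, with a range from 15000 nM to 110000 nM. The estimated step is a 1.0-fold higher number from compound 2 to compound 3 (0.02 log units; within the scatter), a change expected to stay inside the scatter.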

Compound 3, half-maximal inhibitory concentration: 84600 nM
The estimate for compound 3 lay 2.1-fold (0.33 log units) below the measured number, and the stated range covers the measured number.
By their numbers in this assay, from the lowest: compounds 2, 1 and 3 (each within the scatter of the next, the first and the last beyond it).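

Going by these compounds alone, the aryl group on the carbonyl carbon is not wholly without consequence in this assay: 3-methoxyphenyl in place of 4-hydroxyphenyl gives a 2.2-fold higher number from compound 2 to compound 3 (0.34 log units; beyond the scatter), the first step at this site to pass the scatter, though only modestly. The same group in place of thiophen-2-yl gives a 1.8-fold higher number from compound 1 to compound 3 (0.26 log units; within the scatter), which stays within the scatter, so compound 3 cannot be ordered against compound 1 and only the two ends of the three-compound set stand apart. No measurement is available that bears on the origin of the step from 4-hydroxyphenyl to 3-methoxyphenyl.

This exchange alters the substituent and its ring position together, so the shown compounds cannot separate the loss of the hydroxyl from the move to the 3-position; 3-hydroxyphenyl and 4-methoxyphenyl would be the groups to divide those two changes. Going by these compounds, whether any group at this carbonyl carbon gives a step toward lower numbers beyond the scatter also stays open, for instance an aminophenyl, a carboxylic acid on the phenyl ring, or a longer alkyl chain in place of the aromatic ring.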